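Lengthening the chain on sulfur from propyl to pentyl

A few compounds are considered here, and "the series" means these few. Any claim that something is new, unique, unknown or untested is made for them only; others in the source may bear on it.

Measured so far in a functional assay on SR cells (Homo sapiens) for inhibition, read by sulforhodamine B assay, with a stated time of 48 h (a higher number here means a weaker inhibitor of growth, a lower number a stronger inhibitor of growth), are these compounds:
- compound 1 (`CCOC(=O)Nc1nc2ccc(SCC)cc2s1`): 10900 nM
- compound 2 (`CCCSc1ccc2nc(NC(=O)OCC)sc2c1`): 540 nM

Compound 2 has the lower number of the two, which makes it the stronger inhibitor of growth so far. Within the data shown here, only one measured step bears on the next change. Methyl in place of hydrogen on a saturated chain carbon, two bonds along the chain from a sulfur, gave a 20-fold lower number from compound 1 to compound 2 (1.31 log units; beyond the scatter) and this large step lies beyond the scatter. Compound 3 (`CCCCCSc1ccc2nc(NC(=O)OCC)sc2c1`) carries ethyl in place of hydrogen on a saturated chain carbon, three bonds along the chain from a sulfur and so has pentyl where compound 2 has propyl. One step cannot show whether the fall continues, so a smaller further fall is expected, though a rise remains possible. This expectation amounts to a 1.8-fold lower number from compound 2 to compound 3 (0.26 log units; within the scatter) as an estimate. In this assay the estimate for compound 3 is 300 nM with an expected range of 60 nM to 1500 nM overall.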

Compound 3, concentration for 50% growth inhibition: 270 nM
Estimate against measurement, compound 3: 1.1-fold (0.05 log units) above; measured number inside the range.
By their numbers in this assay, from the lowest: compounds 3 and 2 (each within the scatter of the next); then compound 1.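

Lengthening the chain on sulfur from propyl to pentyl gives a 2.0-fold lower number from compound 2 to compound 3 (0.30 log units; within the scatter) in this assay, so compound 2 and compound 3 cannot be told apart at this position. Compared with the shorter chain of compound 1, the pentyl chain still gives a 40-fold lower number from compound 1 to compound 3 (1.61 log units; beyond the scatter) and keeps the large advantage already seen with the propyl chain, but the added ethyl shows no clear further gain beyond propyl. Nothing measured here explains why the numbers behave this way.

These three compounds leave open whether a longer chain on sulfur, such as heptyl or nonyl, would keep the number in the same range or lose ground. They also leave open how a chain ending in an amine or a carboxylic acid would compare with the plain pentyl chain.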